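Pyridin-2-yl in place of phenyl: cytotoxicity notes

This account rests on a few compounds, and the source may have more. Where it says the series, first, only, none or still open, it means among the compounds named here.

In an ADME assay on MT4 cells (Homo sapiens) for cytotoxicity, read by MTT assay (a lower number here means that less compound is tolerated, a higher number that more compound is tolerated), compound 1 (`O=c1cc(Cc2c(F)cccc2F)nc(SCc2c(F)cccc2F)[nH]1`) gives > 66000 nM as a limit of the assay. Compound 3 (`Cc1c(Cc2c(F)cccc2F)nc(SCc2ccccc2)[nH]c1=O`) gives > 70000 nM as a limit too, so it stands without an actual number. Among the compounds with values here, compound 2 (`O=C(CSc1nc(Cc2c(F)cccc2F)cc(=O)[nH]1)c1ccc([N+](=O)[O-])cc1`) gives 22000 nM as the only actual number so far.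

Compound 4 (`Cc1c(Cc2c(F)cccc2F)nc(SCc2ccccn2)[nH]c1=O`) carries pyridin-2-yl in place of phenyl on a saturated chain carbon bound to a sulfur. Within the data shown here, no measured pair shows this change. In this assay a small expected move towards less tolerated compound is assumed, possibly none beyond the scatter. The expected size is an at least 1.4-fold lower number from compound 3 to compound 4 (0.14 log units; that floor lies within the scatter) on this estimate. Compound 4 is estimated at 50000 nM with an expected range from 18000 nM to 100000 nM as the working figure.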

Compound 4, half-maximal cytotoxic concentration: > 70000 nM
Compound 4 gave a limit, no number (the forecaster's own chance of this, stated with the estimate: 55%); middle value at least 1.4-fold (0.14 log units) from the limit.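

In this assay compound 3 and compound 4 both stand at a limit, so no step between them can be read: the limit of > 70000 nM in this assay, at which 2 of the 4 values shown sit.

From the compounds shown here alone, whether pyridin-2-yl in place of phenyl changes the half-maximal cytotoxic concentration at all remains open.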